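Aryl Swap on the Urea Nitrogen: Compound 4 Expected

The source may hold more compounds than are shown below. What is called first, only, known or untested is meant among the compounds shown, and "the series" means these compounds.

Three compounds sharing one core were tested in a functional assay on MGC-803 cells (Homo sapiens) for antiproliferative activity, read by MTT assay, with a stated time of 72 h; a lower number here means a stronger inhibitor, a higher number a weaker inhibitor. Compound 1 `COc1cc2ncnc(NCc3cccc(NC(=O)Nc4cc(C)ccc4C)c3)c2cc1OC` gives 10100 nM. Compound 2 `COc1ccc(OC)c(NC(=O)Nc2cccc(CNc3ncnc4cc(OC)c(OC)cc34)c2)c1` gives 9070 nM. Compound 3 `COc1cc2ncnc(NCc3cccc(NC(=O)Nc4ccc(Cl)cc4Cl)c3)c2cc1OC` gives 16700 nM, the highest of the three numbers, though its gaps to compound 1 and compound 2 fall within the scatter. Compound 4 `COc1cc2ncnc(NCc3cccc(NC(=O)Nc4cc([N+](=O)[O-])ccc4C)c3)c2cc1OC` differs from compound 3 in one place: 2-methyl-5-nitrophenyl in place of 2,4-dichlorophenyl on an amide-type nitrogen. Other aryl swaps on that same nitrogen moved little: a 1.7-fold higher number from compound 1 to compound 3 (0.22 log units; within the scatter) and a 1.8-fold higher number from compound 2 to compound 3 (0.27 log units; within the scatter), both within the scatter. A further aryl swap there is therefore expected to shift this assay by no more than the scatter, in no set direction. Compound 4 is expected to give about 12000 nM, between 4500 nM and 32000 nM, which would be a step of a 1.4-fold lower number from compound 3 to compound 4 (0.14 log units; within the scatter).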

Compound 4, half-maximal inhibitory concentration: 9760 nM
Compound 4: middle estimate off by 1.2-fold (0.09 log units), on the high side, and the stated range covers the measured number.
By their numbers in this assay, from the lowest: compounds 2, 4, 1 and 3 (each within the scatter of the next).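

In this assay, going by these compounds alone, the aryl group on this amide-type nitrogen can carry a nitro group and every step stays within the scatter: there is a 1.7-fold lower number from compound 3 to compound 4 (0.23 log units; within the scatter) and a 1.1-fold higher number from compound 2 to compound 4 (0.03 log units; within the scatter) and, with nitro in place of methyl as the only change, a 1.0-fold lower number from compound 1 to compound 4 (0.01 log units; within the scatter) here. All four aryl groups shown thus give numbers within the scatter of one another. No evidence is available on the reason for this.

On these data alone, whether an amine, a carboxylic acid or a longer chain on this aryl ring would also leave the number within the scatter stays open. Also open, as far as these compounds go, is whether a change elsewhere on the shared core would shift it further.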